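Ether side chain swap on the shared core: compound 1 to compound 3

A few compounds are considered here, and "the series" means these few. Any claim that something is new, unique, unknown or untested is made for them only; others in the source may bear on it.

Measured so far:
compound 1 `CC1CC1COc1cccc2ccc(N)nc12` — 1640 nM
compound 2 `Nc1ccc2cccc(OCC3CC3)c2n1` — > 2000 nM

Going by the values given here, in an assay on cells with melanin-concentrating hormone receptor 1 (Homo sapiens) as the target, read by radioligand binding (a lower number here means a stronger inhibitor, a higher number a weaker inhibitor), compound 1 gives 1640 nM, the only actual number in the set. Compound 2 returns only a limit, > 2000 nM, in line with the limit of > 2000 nM in this assay, at which 1 of the 2 values shown sits. Among the compounds with values here, the single measured step, an at least 1.2-fold higher number from compound 1 to compound 2 (0.08 log units; that floor lies within the scatter), is hydrogen in place of methyl on a saturated ring carbon, and its floor lies within the scatter, so it fixes no direction.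

Compound 3 `CCOCC(C)Oc1cccc2ccc(N)nc12` carries the change (a group of 6 heavy atoms (5 carbon, 1 oxygen; no ring) in place of a group of 5 heavy atoms (5 carbon; one three-membered non-aromatic ring of carbon only), on an oxygen on an aromatic ring). From the compounds shown here alone, the measured step touches the same side chain on the oxygen, but an open chain with an ether oxygen is untested, so it bears only loosely on this step. The expected step is a 1.2-fold higher number from compound 1 to compound 3 (0.09 log units; within the scatter), no further than the scatter. Compound 3 is therefore estimated at 2000 nM, with a range of 800 nM to 5000 nM.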

Compound 3, half-maximal inhibitory concentration: 1070 nM
Compound 3: the middle estimate sits 1.9-fold (0.27 log units) above what was measured, and the stated range covers the measured number.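

In this assay the open chain with an ether oxygen replaces (2-methylcyclopropyl)methyl on an oxygen on an aromatic ring, giving a 1.5-fold lower number from compound 1 to compound 3 (0.19 log units; within the scatter), so at this position, losing the three-membered ring and gaining a hydrogen-bond acceptor produces no change that can be told from the scatter. Compound 2 stands as a limit and not a number: the limit of > 2000 nM in this assay, at which 1 of the 3 values shown sits. The step of an at least 1.8-fold lower number from compound 2 to compound 3 (0.27 log units; that floor lies within the scatter) therefore offers only a floor, and it fixes no direction.

The compounds shown do not separate the ether oxygen of compound 3 from the rest of its chain. Also open, from the compounds shown here alone, is how this position answers to an amine, a carboxylic acid or a longer all-carbon chain on the same oxygen.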